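The source may hold more compounds than are shown below. What is called first, only, known or untested is meant among the compounds shown, and "the series" means these compounds.

Compound 1, `O=C(C1COc2ccccc2O1)N1N=C(c2ccc(Br)cc2)CC1c1ccccc1F`, gives 8030 nM in a functional assay on WM 266-4 cells (Homo sapiens) for inhibition, read by MTT assay, with a stated time of 24 h; a higher number here means a weaker inhibitor of growth, a lower number a stronger inhibitor of growth.
Compound 2, `COc1ccc(C2CC(c3ccc(Br)cc3)=NN2C(=O)c2ccc3c(c2)OCCO3)cc1`, gives 5680 nM.
Compound 3, `COc1ccc(C2=NN(C(=O)c3ccc4c(c3)OCCO4)C(c3ccccc3F)C2)cc1`, gives 3470 nM.

Compound 3 has the lowest of the three numbers. Its distance to compound 2 lies within the scatter, so the two cannot be put in order; its distance to compound 1 lies beyond the scatter. Compound 4, `O=C(c1ccc2c(c1)OCCO2)N1N=C(c2ccc(Br)cc2)CC1c1ccccc1F`, differs from compound 3 by bromo in place of methoxy on an aromatic carbon. Among the compounds with values here, no measured pair shows this change on its own, so its size is not known from the data. A modest move toward a higher number in this assay is expected, roughly the step of a 1.4-fold higher number from compound 3 to compound 4 (0.16 log units; within the scatter), which stays close to the scatter. Compound 4 is therefore estimated at 5000 nM, with a range from 2000 nM to 12000 nM.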

Compound 4, concentration for 50% growth inhibition: 580 nM
For compound 4 the middle estimate is 8.6-fold (0.94 log units) above the measured one, outside the stated range (below it).
By their numbers in this assay, from the lowest: compound 4; then compounds 3, 2 and 1 (each within the scatter of the next, the first and the last beyond it).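

In this assay, within the data shown here, 4-bromophenyl in place of 4-methoxyphenyl gives a 6.0-fold lower number from compound 3 to compound 4 (0.78 log units; beyond the scatter), so this position, whose change no earlier pair had isolated, clearly affects growth inhibition. With the bromo present, two other changes also matter: 2-fluorophenyl in place of 4-methoxyphenyl on a saturated ring carbon gives a 9.8-fold lower number from compound 2 to compound 4 (0.99 log units; beyond the scatter), and 2,3-dihydro-1,4-benzodioxin-6-yl in place of 2,3-dihydro-1,4-benzodioxin-2-yl on a carbonyl carbon gives a 14-fold lower number from compound 1 to compound 4 (1.14 log units; beyond the scatter). Nothing available explains these steps.

The compounds shown leave open how chloro, trifluoromethyl or an amine would compare with bromo at this position. They also leave open whether the bromo step holds with other groups elsewhere on the core.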